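Dihydroxypropyl to Hydroxycyclohexyl on the Thioether Sulfur

A few compounds are considered here, and "the series" means these few. Any claim that something is new, unique, unknown or untested is made for them only; others in the source may bear on it.

Compound 1 `CC(O)CSc1nc(NCc2ccc(-c3ccccn3)cc2)c2[nH]nc(C(C)C)c2n1` gives 62 nM in a functional assay on HT cells (Homo sapiens) for antiproliferative activity, read by fluorescence, with a stated time of 72 h; a lower number here means a stronger inhibitor of growth, a higher number a weaker inhibitor of growth
Compound 2 `CC(C)c1n[nH]c2c(NCc3ccc(-c4ccccn4)cc3)nc(SCC(O)CO)nc12` gives 21 nM in this assay

Compound 2 holds the lowest of the two numbers in this assay; the step of a 3.0-fold lower number from compound 1 to compound 2 (0.47 log units; beyond the scatter) separates it from compound 1 and lies beyond the scatter. Compound 3 `CC(C)c1n[nH]c2c(NCc3ccc(-c4ccccn4)cc3)nc(SC3CCCCC3O)nc12` is still to be measured. It differs from compound 2 by 2-hydroxycyclohexyl in place of 2,3-dihydroxypropyl on a sulfur. Among the measured compounds shown here, the only measured step that bears on this, a 3.0-fold lower number from compound 1 to compound 2 (0.47 log units; beyond the scatter), lowered the number when a hydroxy entered. Since one hydroxy now leaves and one six-membered non-aromatic ring of carbon only enters, compound 3 is expected to show a 2.4-fold higher number from compound 2 to compound 3 (0.38 log units; beyond the scatter), a modest rise. Compound 3 is estimated at 50 nM, between 15 nM and 160 nM.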

Compound 3, concentration for 50% growth inhibition: 636 nM
Compound 3: middle estimate off by 13-fold (1.10 log units), on the low side; measured number above the stated range.
By their numbers in this assay, from the lowest: compound 2; then compound 1; then compound 3.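

In this assay the sulfur position proved far more sensitive than the earlier hydroxy step suggested, with a 30-fold higher number from compound 2 to compound 3 (1.48 log units; beyond the scatter) marking the largest change so far. The rise remains at a 10-fold higher number from compound 1 to compound 3 (1.01 log units; beyond the scatter) even though both groups in that step carry a hydroxy, so the hydroxy count alone does not describe this position. Nothing measured here accounts for the loss.

The compounds shown leave open whether the ring itself or its particular substitution drives the rise, and whether a longer chain bearing hydroxy groups or a cyclohexyl ring bearing an amine would bring the number back toward that of compound 2.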